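A Dichlorophenyl Swap Tested on Lung Cancer Cells

The compounds below may be only part of what the source reports. "The series", "measured", "known", "first", "only" and "open" are said of these compounds alone.

Compound 3 `COc1ccc(-n2cc(-c3ccccc3)c(-c3ccc4c(c3)NC(=O)CO4)n2)cc1` stands lowest of the three compounds measured in a functional assay on A549 cells (Homo sapiens) for cytotoxicity, read by colorimetric assay and MTT assay, with a stated time of 3 days, tested at 20 uM (a lower number here means a stronger effect, a higher number a weaker effect of the compound at the concentration tested), where compound 3 gives 42.6%. Compound 1 `O=C1COc2ccc(-c3nn(-c4ccc(Br)cc4)cc3-c3ccccc3)cc2N1` gives 58.8% in this assay, and compound 2 `O=C1COc2ccc(-c3nn(-c4ccc(F)cc4)cc3-c3ccccc3)cc2N1` gives 56.4%. Both steps toward compound 3 lie beyond the scatter: a number 16.2 percentage points lower from compound 1 to compound 3 (beyond the scatter) and a number 13.8 percentage points lower from compound 2 to compound 3 (beyond the scatter), whereas a number 2.4 percentage points lower from compound 1 to compound 2 (within the scatter). Compound 4 `O=C1COc2ccc(-c3nn(-c4cc(Cl)cc(Cl)c4)cc3-c3ccccc3)cc2N1` differs from compound 3 by 3,5-dichlorophenyl in place of 4-methoxyphenyl on an aromatic nitrogen. For the measured compounds named here, the steps that bear on this change are those in which methoxy replaced bromo or fluoro and the number fell modestly; going from methoxy to a ring carrying two chloro groups is expected to reverse that, so a modest rise is expected, a number 14.4 percentage points higher from compound 3 to compound 4 (beyond the scatter). Compound 4 is therefore estimated at 57%, between 45% and 70%.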

Compound 4, a percentage reported as activity, at one concentration (the size of the read-out at that concentration, not a potency): 70.2%
For compound 4 the middle estimate is 13.2 percentage points below the measured one, outside the stated range (above it).
By their numbers in this assay, from the lowest: compound 3; then compounds 2 and 1 (each within the scatter of the next); then compound 4.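

In this assay the aromatic nitrogen now carries the group with the weakest effect of the four, 3,5-dichlorophenyl, with a number 27.6 percentage points higher from compound 3 to compound 4 (beyond the scatter) and a number 13.8 percentage points higher from compound 2 to compound 4 (beyond the scatter) and a number 11.4 percentage points higher from compound 1 to compound 4 (beyond the scatter) as well. The 4-bromophenyl, 4-fluorophenyl and 4-methoxyphenyl rings had not shown that changing this ring could lift the number past all three. Nothing measured here explains the rise.

Going by these compounds, whether it follows from having two chloro groups or from where they sit stays open. A 4-chlorophenyl ring, or a phenyl ring bearing an amine, could help separate these possibilities.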